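Anilino variation on a shared tricyclic core

The compounds below may be only part of what the source reports. "The series", "measured", "known", "first", "only" and "open" are said of these compounds alone.

compound 1 `Cc1ccc(NC2=CC(=O)c3nc4n(c3C2=O)[C@H]2OC[C@@H](O)[C@H]2OC4)cc1`: in a functional assay on HeLa cells (Homo sapiens) for inhibition, read by sulforhodamine B assay (on this read-out higher numbers stand for weaker inhibition and lower numbers for stronger inhibition), compound 1 gives 3860 nM.
compound 2 `Cc1ccc(NC2=CC(=O)c3c(nc4n3[C@H]3OC[C@@H](O)[C@H]3OC4)C2=O)cc1`: in this assay compound 2 gives 6590 nM.
compound 3 `O=C1C(N2CCCC2)=CC(=O)c2c1nc1n2[C@H]2OC[C@@H](O)[C@H]2OC1`: in this assay compound 3 gives only a limit, > 16000 nM.

Compound 1 holds the lower of the two numbers; compound 2 lies within the scatter of it, so no order between the two can be claimed. Compound 3 sits at the limit of this assay, (the limit of > 16000 nM in this assay, at which 1 of the 3 values shown sits). Among the compounds with values here, the one measured step, an at least 2.4-fold higher number from compound 2 to compound 3 (0.38 log units; beyond the scatter), replaces the whole anilino group and weakens inhibition.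

Compound 4 `COc1ccccc1NC1=CC(=O)c2nc3n(c2C1=O)[C@H]1OC[C@@H](O)[C@H]1OC3` differs from compound 1 in one place: 2-methoxyphenyl in place of 4-methylphenyl on an amine nitrogen. Within the data shown here, no measured step alters the aryl part of the (4-methylphenyl)amino group while keeping the amine nitrogen, so the step from compound 1 to compound 4 has no direct precedent here. Compound 4 is therefore expected to stay close to compound 1, with a 1.2-fold higher number from compound 1 to compound 4 (0.07 log units; within the scatter) as the estimated step, not beyond the scatter. For compound 4 the estimate in this assay is 4500 nM, within a range of 1500 nM to 14000 nM.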

Compound 4, half-maximal inhibitory concentration: 2950 nM
Compound 4: middle estimate off by 1.5-fold (0.18 log units), on the high side; low and high end bracket the measured number.
By their numbers in this assay, from the lowest: compounds 4, 1 and 2 (each within the scatter of the next, the first and the last beyond it). At a limit, above all of these: compound 3.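

In this assay, within the data shown here, 2-methoxyphenyl in place of 4-methylphenyl on the amine nitrogen gives a 1.3-fold lower number from compound 1 to compound 4 (0.12 log units; within the scatter), the first measured step that alters the aryl part while keeping the amine nitrogen. Among these compounds, compound 1 and compound 4 therefore stay within the scatter of each other, whereas the one step that replaces the whole anilino group, an at least 2.4-fold higher number from compound 2 to compound 3 (0.38 log units; beyond the scatter), lies beyond it. Nothing measured in the series gives a reason for this result.

The compounds shown leave open whether an amine or a carboxylic acid on the phenyl ring, or a longer chain on the amine nitrogen in place of the ring, would keep the number in this range. They also leave open whether 2-methoxyphenyl on the core of compound 2 would stay within the scatter of compound 2.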